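The source may hold more compounds than are shown below. What is called first, only, known or untested is meant among the compounds shown, and "the series" means these compounds.

Of the compounds shown here, three sharing a core have been measured in an ADME assay on brain (Rattus norvegicus) for protein binding; a higher number here means a larger unbound share of the compound, a lower number a smaller unbound share. Compound 1 (`Cn1cc(-c2ccc(Cc3cc(C(=O)NC4CCOCC4)nc4c3ccn4C)cn2)cn1`) gives 0.08, and compound 2 (`Cn1ccc2c(Cc3ccc(-c4nccs4)cc3)cc(C(=O)N[C@@H]3CCOC[C@H]3O)nc21`) gives 0.01. Compound 3 (`Cn1ccc(-c2ccc(Cc3cc(C(=O)N[C@@H]4CCCC[C@H]4O)nc4c3ccn4C)cn2)n1`) gives 0.04, a number within the usual scatter of compound 1 and beyond the scatter above compound 2.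

Compound 4 (`Cn1cc(-c2ccc(Cc3cc(C(=O)N[C@@H]4CCCC[C@H]4O)nc4c3ccn4C)cn2)cn1`) has the same atoms as compound 3, joined differently: 1-methyl-1H-pyrazol-4-yl in place of 1-methyl-1H-pyrazol-3-yl on an aromatic carbon. Going by the values given here, no two measured compounds differ in just one place, so the data offer no direct guide to this swap. Compound 1 carries the same 1-methyl-1H-pyrazol-4-yl group and gives 0.08, but its amide portion also differs from that of compound 3, so it is only a weak hint of a slight rise. The expected step, a 1.3-fold higher number from compound 3 to compound 4 (0.10 log units; within the scatter), is small and stays within the scatter. The estimated value for compound 4 is 0.05, with an expected range from 0.025 to 0.09.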

Compound 4, unbound fraction: 0.07
Beside the measured number, compound 4's estimate is 1.4-fold (0.15 log units) below it; measured number inside the range.
By their numbers in this assay, from the lowest: compound 2; then compounds 3, 4 and 1 (each within the scatter of the next).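

Placing 1-methyl-1H-pyrazol-4-yl in place of 1-methyl-1H-pyrazol-3-yl, on the aromatic carbon next to the ring nitrogen, gives a 1.8-fold higher number from compound 3 to compound 4 (0.24 log units; within the scatter) in this assay, the first comparison here that differs in one place only. The amide side can now be read as well: 2-hydroxycyclohexyl in place of oxan-4-yl on an amide-type nitrogen gives a 1.1-fold lower number from compound 1 to compound 4 (0.06 log units; within the scatter), so neither swap moves the unbound fraction beyond the scatter. Nothing at hand explains either result.

On these data alone, it remains open whether a different kind of group at the pyrazole's place, such as a carboxylic acid or an amine, would shift this number beyond the scatter. As far as these compounds go, each swap also appears only once here, so whether it behaves the same alongside other groups on the shared core is unknown.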